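The compounds below may be only part of what the source reports. "The series", "measured", "known", "first", "only" and "open" are said of these compounds alone.

Compound 1 `O=C(C1CCC1)N1CCc2nc(C#Cc3ccccc3)sc2C1` gives 370 nM in an assay on HEK293 cells for negative allosteric modulation of metabotropic glutamate receptor 5 (Homo sapiens), read by FLIPR, with a stated time of 1 h; a lower number here means a stronger inhibitor, a higher number a weaker inhibitor. Compound 2 `O=C(C1CCCCC1)N1CCc2nc(C#Cc3ccccc3)sc2C1` gives > 10000 nM in this assay, which is a limit of the assay rather than a number. Compound 3 `O=C(C1CCCCO1)N1CCc2nc(C#Cc3ccccc3)sc2C1` gives > 10000 nM in this assay, again a limit rather than a number.

Compound 3 therefore stands at the limit (the limit of > 10000 nM in this assay, at which 2 of the 3 values shown sit), where compound 2 also sits, and only compound 1 has a measured number. Moving from the cyclobutyl of compound 1 to a six-membered ring on the carbonyl carbon gave an at least 27-fold higher number from compound 1 to compound 2 (1.43 log units; beyond the scatter) and an at least 27-fold higher number from compound 1 to compound 3 (1.43 log units; beyond the scatter). Between the two six-membered rings the step that the two limits leave unreadable from compound 2 to compound 3 cannot be read, since both values are limits.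

Compound 4 `O=C(N1CCCCC1)N1CCc2nc(C#Cc3ccccc3)sc2C1` differs from compound 3 in one place: piperidin-1-yl in place of oxan-2-yl on a carbonyl carbon. The change keeps a six-membered ring with one hetero atom on the carbonyl carbon. Since compound 2 gives > 10000 nM and compound 3 gives > 10000 nM, both six-membered rings there sit at the limit, and the third one is expected to do the same. The expected step is a step that the limit leaves unreadable from compound 3 to compound 4, no change beyond the scatter. Compound 4 is therefore estimated at 15000 nM in this assay, within 3000 nM to 60000 nM, most likely reported only as a limit.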

Compound 4, half-maximal inhibitory concentration: > 10000 nM
Compound 4 was reported as a limit (the forecaster's own chance of this, stated with the estimate: 70%); the middle value is on the limit's open side.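

In this assay, the loss seen with six-membered rings on this carbonyl carbon extends to piperidin-1-yl, with an at least 27-fold higher number from compound 1 to compound 4 (1.43 log units; beyond the scatter). Cyclohexyl, oxan-2-yl and piperidin-1-yl are now all six-membered rings that leave the core without a measurable number, whether the ring holds no hetero atom, an oxygen or a nitrogen, and the limit is shared by most of the series: the limit of > 10000 nM in this assay, at which 3 of the 4 values shown sit. The steps among compound 2, compound 3 and compound 4 cannot be read, since all three values are limits, so any difference among these rings stays hidden.

On these data alone, it remains open whether a five-membered ring such as cyclopentyl or pyrrolidin-1-yl keeps the activity of compound 1 or already loses it. Also open, as far as these compounds go, is how a smaller ring such as cyclopropyl or azetidin-1-yl, or an open chain such as isopropyl, would compare with the cyclobutyl of compound 1.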